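The source may report more compounds than this note shows. Statements on the series, on what has been measured and on what is new or still open speak of the compounds shown alone.

Working notes on the series. The common core carries a phenyl group and, in the first two members, a para-substituted aryl group. Compound 1 `Clc1ccc(-c2cccn3cc(-c4ccccc4)nc23)cc1`, bearing a chloro group, is measured in an assay on isolated protein for inhibition of aldehyde dehydrogenase 1A1 (Homo sapiens), with a stated time of 5 min (a higher number here means a weaker inhibitor, a lower number a stronger inhibitor), and gives 168000 nM, already a very weak result. Compound 2 `Fc1ccc(-c2cccn3cc(-c4ccccc4)nc23)cc1`, the fluoro analogue, is reported in this assay only as "not active" (no number reported), so no number places it against compound 1; the two results agree only in showing that the series sits at the weak end of what this assay can resolve.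

Compound 3 `c1ccc(-c2cn3cccc(-c4ccccc4)c3n2)cc1` removes the fluoro: hydrogen in place of fluoro on an aromatic carbon. Among the measured compounds shown here, no measured pair shows what such a change does, so no size or direction of step beyond the scatter can be read from the data; the only anchor is that compound 1 is itself barely active. The expectation for compound 3 in this assay is therefore a weak value of about 200000 nM, estimated to lie between 50000 nM and 1000000 nM, with a real chance that only an inactive call is returned.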

Compound 3, half-maximal inhibitory concentration: "not active" (no number reported)
Compound 3: no number reported, so the estimate cannot be set against anything.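

Compound 2 and compound 3 are both reported only as not active in this assay, so no step can be read between them. Nothing available bears on this result. The compounds shown leave open whether the 4-fluorophenyl to phenyl change alters inhibition at all.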